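A few compounds are considered here, and "the series" means these few. Any claim that something is new, unique, unknown or untested is made for them only; others in the source may bear on it.

Compound 1 `CSc1ncnc2c1c(-c1ccccc1)cn2[C@@H]1O[C@H](CO)[C@@H](O)[C@H]1O`: > 20000 nM
Compound 2 `O=c1[nH]cnc2c1c(-c1ccsc1)cn2[C@@H]1O[C@H](CO)[C@@H](O)[C@H]1O`: > 20000 nM
Compound 3 `CSc1ncnc2c1c(-c1ccsc1)cn2[C@@H]1O[C@H](CO)[C@@H](O)[C@H]1O`: > 20000 nM

None of these values is a number; each is a limit of a functional assay on HCT-116 cells (Homo sapiens), read by MTT assay, with a stated time of 72 h; a lower number here means a stronger inhibitor, a higher number a weaker inhibitor. Compound 2 in this assay gives only the limit > 20000 nM. Every value shown so far sits at the limit of > 20000 nM in this assay, at which 3 of the 3 values shown sit. Among the compounds with values here, the single measured step between compounds that differ in one place, a step that the two limits leave unreadable from compound 1 to compound 3, gives no readable size and no direction.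

Compound 4 `O=c1[nH]cnc2c1c(-c1ccccc1)cn2[C@@H]1O[C@H](CO)[C@@H](O)[C@H]1O` has not yet been measured. Its change from compound 2 is phenyl in place of thiophen-3-yl on an aromatic carbon. This is the mirror of the change from compound 1 to compound 3, and that pair yielded nothing readable. Within the data shown here, there is thus no measured step that tells how large a shift to expect in this assay or which way it would go; the only evidence is that all values so far stand at the limit.

Compound 4 is expected also to reach only the limit, estimated at 30000 nM, between 10000 nM and 100000 nM. The expected step is a step that the limit leaves unreadable from compound 2 to compound 4, nothing beyond the scatter.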

Compound 4, half-maximal inhibitory concentration: > 100000 nM
Compound 4 gave a limit, no number; the forecaster's own chance of this, stated with the estimate: 90%; at least 3.3-fold (0.52 log units) between middle value and limit.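

Within the data shown here, compound 2 and compound 4 each give only a limit in this assay, so no step between them can be read. The compounds shown leave open what number, if any, this core would reach in this assay, and whether exchanging phenyl and thiophen-3-yl changes it.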